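Benzamide Without Ring Substituents in a Pyrazole Series

The compounds below may be only part of what the source reports. "The series", "measured", "known", "first", "only" and "open" are said of these compounds alone.

Measured compounds:
compound 1 `COc1cc(-c2nn(-c3cccc(NC(=O)c4cccc(C(F)(F)F)c4)c3)cc2-c2ccncc2)ccc1Cl` – 1320 nM
compound 2 `COc1cc(-c2nn(-c3cccc(NC(=O)Nc4ccc(Cl)c(C(F)(F)F)c4)c3)cc2-c2ccncc2)ccc1Cl` – 833 nM

Compound 2 `COc1cc(-c2nn(-c3cccc(NC(=O)Nc4ccc(Cl)c(C(F)(F)F)c4)c3)cc2-c2ccncc2)ccc1Cl` has the lowest number of the two in a functional assay on MDA-MB-468 cells (Homo sapiens) for inhibition, read by sulforhodamine B assay, with a stated time of 48 h (on this read-out lower numbers stand for stronger inhibition of growth and higher numbers for weaker inhibition of growth), and its nearest neighbour is compound 1 `COc1cc(-c2nn(-c3cccc(NC(=O)c4cccc(C(F)(F)F)c4)c3)cc2-c2ccncc2)ccc1Cl`, which gives 1320 nM in this assay. The single step between them, a 1.6-fold lower number from compound 1 to compound 2 (0.20 log units; within the scatter), stays within the scatter, so on the numbers shown the two compounds cannot be ordered.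

Compound 3 `COc1cc(-c2nn(-c3cccc(NC(=O)c4ccccc4)c3)cc2-c2ccncc2)ccc1Cl` differs from compound 2 in one place: phenyl in place of (4-chloro-3-(trifluoromethyl)phenyl)amino on a carbonyl carbon. Among the compounds with values here, the only measured step touches the same carbonyl carbon: from compound 1 to compound 2 the aryl group was replaced by an aryl-amino group carrying chloro and trifluoromethyl, and the numbers stayed within the scatter. Within the data shown here, no measured pair shows what removing the trifluoromethyl from the ring does. Among the measured compounds shown here, because the one step on this carbonyl was a 1.6-fold lower number from compound 1 to compound 2 (0.20 log units; within the scatter), compound 3 is expected to land near compound 2 or somewhat higher in this assay, estimated as a 2.4-fold higher number from compound 2 to compound 3 (0.38 log units; beyond the scatter). The estimated value for compound 3 in this assay is 2000 nM, with a range from 700 nM to 6000 nM.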

Compound 3, concentration for 50% growth inhibition: 349 nM
Beside the measured number, compound 3's estimate is 5.7-fold (0.76 log units) above it; measured number outside the range, below it.
By their numbers in this assay, from the lowest: compound 3; then compounds 2 and 1 (each within the scatter of the next).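

In this assay, within the data shown here, the bare phenyl on the carbonyl carbon separates from both substituted groups, which compounds 1 and 2 alone could not show, since their single step stayed within the scatter. Hydrogen in place of trifluoromethyl on an aromatic carbon gives a 3.8-fold lower number from compound 1 to compound 3 (0.58 log units; beyond the scatter) and so shows what taking that group off the ring does, while phenyl in place of (4-chloro-3-(trifluoromethyl)phenyl)amino gives a 2.4-fold lower number from compound 2 to compound 3 (0.38 log units; beyond the scatter) on a carbonyl carbon whose other neighbour is an amide-type nitrogen. Compound 3 therefore has the lowest number of the three, with steps to both others beyond the scatter, so neither trifluoromethyl nor the larger 12-heavy-atom group is needed for growth inhibition at this level, and nothing at hand explains the change in either step.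

The compounds shown leave open whether the lower number belongs to the plain phenyl itself or whether a small ring substituent such as fluorine, methoxy or an amine would keep or improve it. They also leave open how an unsubstituted phenylamino group on the same carbonyl would compare, which would separate the effect of the amino link from that of the chloro and trifluoromethyl groups.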